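Capping a Phenol: From Compound 1 to Compound 3

This account rests on a few compounds, and the source may have more. Where it says the series, first, only, none or still open, it means among the compounds named here.

Measured compounds:
- compound 1, `O=C(Nc1cccc(-n2cc(-c3ccncc3)c(-c3cc(O)cc(Cl)c3)n2)c1)Nc1ccc(Cl)c(Cl)c1`; in a functional assay on HCT-15 cells (Homo sapiens) for inhibition, read by sulforhodamine B assay, with a stated time of 48 h, tested at 0.01 uM (a higher number here means a weaker effect of the compound at the concentration tested, a lower number a stronger effect), compound 1 gives 59%
- compound 2, `COc1cc(Cl)cc(-c2nn(-c3cccc(NC(=O)Nc4cc(C(F)(F)F)cc(C(F)(F)F)c4)c3)cc2-c2ccncc2)c1`; in this assay compound 2 gives 93%

Of the two numbers, compound 1 stands lowest, and so shows the stronger effect at the concentration tested. Its nearest neighbour is compound 2, whose number lies higher by a margin beyond the usual scatter. Compound 1 and compound 2 differ in more than one place, so no single step can be read between them; their two values simply show that compound 2 is the weaker of the pair.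

Compound 3, `COc1cc(Cl)cc(-c2nn(-c3cccc(NC(=O)Nc4ccc(Cl)c(Cl)c4)c3)cc2-c2ccncc2)c1`, has not yet been measured. It differs from compound 1 in one place: methyl in place of hydrogen on an oxygen on an aromatic ring. For the measured compounds named here, no measured pair shows this change on its own. Compound 2 carries the same methoxy group and sits higher than compound 1, but it also carries a different urea aryl group, so its value cannot be assigned to the methylation alone. On that basis a modest step toward a higher number is expected in this assay, though one that may not exceed the scatter. Compound 3 is expected to give 72% in this assay, within a range from 52% to 92%. The expected step of a number 13 percentage points higher from compound 1 to compound 3 (beyond the scatter) is thus a slight weakening.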

Compound 3, a percentage reported as activity, at one concentration (the size of the read-out at that concentration, not a potency): 93%
Compound 3: middle estimate off by 21 percentage points, on the low side; measured number outside the range, above it.
By their numbers in this assay, from the lowest: compound 1; then compounds 2 and 3 (each within the scatter of the next).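

Capping the phenol can now be read on its own: with the urea aryl group of compound 1 kept and nothing else altered, going from hydroxy to methoxy yields a number 34 percentage points higher from compound 1 to compound 3 (beyond the scatter) in this assay as a large step for the addition of a single methyl. The free hydroxy on this ring therefore matters at the concentration tested. Compound 3 gives 93% and stands within the scatter of compound 2, which gives 93% with the same methoxy group. The data offer no explanation of this step.

Going by these compounds, whether the effect depends on the hydroxy itself or on the absence of any cap remains open, as an amine, a fluorine or a carboxylic acid at this place, or a longer chain such as ethoxy on the oxygen, would be needed to tell. On these data alone, it is also open whether the hydroxy would give a comparable step alongside the urea aryl group of compound 2, and how the step would look at other concentrations.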